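This account rests on a few compounds, and the source may have more. Where it says the series, first, only, none or still open, it means among the compounds named here.

Of the compounds shown here, three have been measured so far.

Compound 1 `C=C1C(=O)O[C@H]2CC3=C[C@H](C/C(C)=C/[C@@H](OC(=O)c4ccc(-c5ccccc5)cc4)[C@H]12)OC3=O` gives 3500 nM
Compound 2 `C=C1C(=O)O[C@H]2CC3=C[C@H](C/C(C)=C/[C@@H](OC(=O)CCCCBr)[C@H]12)OC3=O` gives > 10000 nM (a limit)
Compound 3 `C=C1C(=O)O[C@H]2CC3=C[C@H](C/C(C)=C/[C@@H](OC(=O)C4CC4)[C@H]12)OC3=O` gives 3000 nM

In a functional assay on NCI-H460 cells (Homo sapiens) for cytotoxicity, read by MTT assay, with a stated time of 48 h (a higher number here means a weaker inhibitor, a lower number a stronger inhibitor), the reading for compound 2 is > 10000 nM, which is a limit of the assay and not a number. Compound 1 and compound 3 both have numbers, and these lie within the usual scatter of each other.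

Compound 4 `C=C1C(=O)O[C@H]2CC3=C[C@H](C/C(C)=C/[C@@H](OC(=O)CC(C)C)[C@H]12)OC3=O` differs from compound 2 at one place, with isopropyl in place of 3-bromopropyl on a saturated chain carbon bound to a carbonyl carbon. The counted change is isopropyl in place of 3-bromopropyl on a saturated chain carbon bound to a carbonyl carbon, and cut one bond further out it reads 4-bromobutyl to isobutyl.

Among the compounds with values here, one measured step bears on this change. The step of an at least 3.3-fold lower number from compound 2 to compound 3 (0.52 log units; beyond the scatter) also removes the 4-bromobutyl, although cyclopropyl enters there and isobutyl enters in compound 4. As far as these compounds go, that step starts from a limit, so its full size stays open. Going by compound 3 at 3000 nM, a step of similar size towards a lower number is expected in this assay. A reading at the limit remains possible for compound 4.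

That expectation amounts to an estimated at least 2.5-fold lower number from compound 2 to compound 4 (0.39 log units; beyond the scatter) here. For compound 4 the estimate is 4000 nM, with an expected range from 1800 nM to 10000 nM.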

Compound 4, half-maximal inhibitory concentration: 3800 nM
Estimate against measurement, compound 4: 1.1-fold (0.02 log units) above; measured number inside the range.
By their numbers in this assay, from the lowest: compounds 3, 1 and 4 (each within the scatter of the next). At a limit, above all of these: compound 2.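

In this assay, isobutyl in place of 4-bromobutyl gives an at least 2.6-fold lower number from compound 2 to compound 4 (0.42 log units; beyond the scatter), so cyclopropyl is no longer the only group shown to bring a reading down from that of the bromine-bearing chain. The ring itself is not needed to reach this level, since the move from the ring to the open branched chain gives a 1.3-fold higher number from compound 3 to compound 4 (0.10 log units; within the scatter), and in this assay the two groups cannot be told apart. The reading of compound 2 is a limit and not a number, and the full size of the step away from it stays open because of that: the limit of > 10000 nM in this assay, at which 1 of the 4 values shown sits.

As far as these compounds go, what remains open is whether the bromine or the length of the 4-bromobutyl chain goes with the limit of compound 2, a question on which a plain butyl chain or a longer unbranched chain would bear. Also open is how the reading would respond to an amine or a carboxylic acid on a saturated chain carbon bound to a carbonyl carbon, as none of the groups shown there carries either.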